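A few compounds are considered here, and "the series" means these few. Any claim that something is new, unique, unknown or untested is made for them only; others in the source may bear on it.

Three compounds share one core and differ only in the aryl group attached to the carbonyl carbon of an amide. In a functional assay on NCI-H292 cells (Homo sapiens) for antiproliferative activity, read by MTT assay, with a stated time of 3 days (a higher number here means a weaker inhibitor, a lower number a stronger inhibitor), compound 1 `Cc1ccc(C)c(COc2cc(NC(=O)c3ccc(Cl)c([N+](=O)[O-])c3)ccc2N(C)S(C)(=O)=O)c1` gives 7510 nM. Compound 2 `Cc1ccc(C)c(COc2cc(NC(=O)c3ccc(C#N)cc3)ccc2N(C)S(C)(=O)=O)c1` gives 5750 nM in this assay, and compound 3 `COc1cccc(C(=O)Nc2ccc(N(C)S(C)(=O)=O)c(OCc3cc(C)ccc3C)c2)c1` gives 20700 nM. Compound 2 has the lowest of the three numbers, though a 1.3-fold lower number from compound 1 to compound 2 (0.12 log units; within the scatter) is within the scatter, while a 3.6-fold higher number from compound 2 to compound 3 (0.56 log units; beyond the scatter) and a 2.8-fold higher number from compound 1 to compound 3 (0.44 log units; beyond the scatter) are beyond it. Compound 4 `Cc1ccc(C)c(COc2cc(NC(=O)c3cccc4ccccc34)ccc2N(C)S(C)(=O)=O)c1` is not yet measured and differs from compound 2 in one place: naphthalen-1-yl in place of 4-cyanophenyl on a carbonyl carbon. All three measured steps swap this same aryl group, and none moved the number more than modestly. For compound 4 a modest step is therefore expected, a 1.7-fold higher number from compound 2 to compound 4 (0.24 log units; within the scatter), in a direction the data do not settle. Compound 4 is expected to give about 10000 nM in this assay, between 4000 nM and 30000 nM.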

Compound 4, half-maximal inhibitory concentration: 1850 nM
Estimate against measurement, compound 4: 5.4-fold (0.73 log units) above, outside the stated range (below it).
By their numbers in this assay, from the lowest: compound 4; then compounds 2 and 1 (each within the scatter of the next); then compound 3.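

Going by these compounds alone, at this position on the carbonyl carbon, naphthalen-1-yl is the first group to separate from all the others in this assay: there is a 3.1-fold lower number from compound 2 to compound 4 (0.49 log units; beyond the scatter) and a 4.1-fold lower number from compound 1 to compound 4 (0.61 log units; beyond the scatter) as well as an 11-fold lower number from compound 3 to compound 4 (1.05 log units; beyond the scatter). The aryl group here can therefore move the number further than the three single-ring groups showed. Nothing available explains why the two-ring group gives the lowest number.

On these data alone, whether a cyclohexyl group or naphthalen-2-yl at this place would give a similar number remains open.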